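This account rests on a few compounds, and the source may have more. Where it says the series, first, only, none or still open, it means among the compounds named here.

Measured compounds in a functional assay on MCF7 cells (Homo sapiens) for antiproliferative activity, read by MTT assay, with a stated time of 48 h; a lower number here means a stronger inhibitor, a higher number a weaker inhibitor:
- compound 1 `CCOC(=O)CN(Cc1ccccc1)c1nc(NCc2cccc(OC)c2)ncc1[N+](=O)[O-]` gives 57400 nM.
- compound 2 `CCOC(=O)CNc1nc(Nc2ccc(Cl)cc2)ncc1[N+](=O)[O-]` reaches only the assay limit, > 100000 nM.

Of the two numbers shown for this assay, compound 1 carries the only finite half-maximal inhibitory concentration; the other entry is a limit and not a number. The limit of compound 2 is the assay ceiling (the limit of > 100000 nM in this assay, at which 1 of the 2 values shown sits), and nothing finer can be read from it. Among the measured compounds shown here, no step between these two compounds is computed, since they differ in more than one place, so the pair shows only that compound 1 returns a value and compound 2 does not.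

Compound 3 `CCOC(=O)CN(Cc1ccccc1)c1nc(Nc2cc(OC)c(OC)c(OC)c2)ncc1[N+](=O)[O-]` is not yet measured. It differs from compound 1 by one change: 3,4,5-trimethoxyphenyl in place of 3-methoxybenzyl on a nitrogen on an aromatic ring. The shared core, the ethyl ester chain on its first nitrogen, the benzyl on that same nitrogen and the nitro group are kept.

For the measured compounds named here, with no measured step of this kind on record, the expectation for the step from compound 1 to compound 3 is a modest one, a 1.1-fold higher number from compound 1 to compound 3 (0.05 log units; within the scatter), of a size not clearly beyond the scatter and in either direction. Compound 3 is accordingly estimated at 65000 nM, within 20000 nM to 200000 nM, with a real chance that this assay again reports only its limit.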

Compound 3, half-maximal inhibitory concentration: > 100000 nM
Compound 3 was reported as a limit; the forecaster's own chance of this, stated with the estimate: 40%; middle value at least 1.5-fold (0.18 log units) away from the limit.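

In this assay the step at this nitrogen reads an at least 1.7-fold higher number from compound 1 to compound 3 (0.24 log units; that floor lies within the scatter); the entry for compound 3 is a limit and not a number, so the step is a floor only. Swapping 3-methoxybenzyl for 3,4,5-trimethoxyphenyl on a nitrogen on an aromatic ring therefore brings no gain over compound 1, while the true size of any loss stays unknown and the floor does not establish a loss beyond the scatter. Compound 1 remains the only compound shown with a finite number, and the reading at this position now runs into the assay limit: the limit of > 100000 nM in this assay, at which 2 of the 3 values shown sit.

The step joins two differences, benzyl against phenyl and one methoxy against three, and the compounds shown do not separate them. Also open, from the compounds shown here alone, is whether a plain phenyl or a 3-methoxyphenyl on this nitrogen, or a carboxylic acid in place of the ethyl ester, would return a finite number in this assay.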